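A few compounds are considered here, and "the series" means these few. Any claim that something is new, unique, unknown or untested is made for them only; others in the source may bear on it.

Compound 2 `N#C/N=C1\N(CCCCCCOc2ccc(Cl)cc2)C(=O)CCN1c1ccncc1` is the weaker of the two measured compounds. In a functional assay on HA22T cells for cytotoxicity against HA22T cell line (Homo sapiens) (a higher number here means a weaker inhibitor, a lower number a stronger inhibitor), compound 2 gives 3050 nM, the highest of the two numbers at hand, while compound 1 `N#C/N=C1\N(CCCCCCOc2ccc(Cl)cc2)C(=O)C(c2ccccc2)N1c1ccncc1` gives 526 nM in this assay, a gap that is beyond the usual scatter. The two differ in more than one place, so only what their values show can be said. Compound 3 `N#C/N=C1\N(CCCCCCCOc2ccc(Cl)cc2)C(=O)CCN1c1ccncc1` is not yet measured. It differs from compound 2 by (4-chlorophenoxy)methyl in place of 4-chlorophenoxy on a saturated chain carbon, six bonds along the chain from an amide-type nitrogen in a ring. Going by the values given here, no measured pair shows this kind of change in the chain, so no step along that line exists to lean on. The expected step from compound 2 to compound 3 a 1.0-fold lower number from compound 2 to compound 3 (0.01 log units; within the scatter) is small and not beyond the scatter, in either direction. Compound 3 is therefore estimated to give 3000 nM in this assay, within a range from 1200 nM to 7500 nM.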

Compound 3, half-maximal inhibitory concentration: 7560 nM
The estimate for compound 3 lay 2.5-fold (0.40 log units) below the measured number; measured number outside the range, above it.
By their numbers in this assay, from the lowest: compound 1; then compound 2; then compound 3.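

In this assay, the chain proves to be a position where a single change registers: (4-chlorophenoxy)methyl in place of 4-chlorophenoxy on a saturated chain carbon, six bonds along the chain from an amide-type nitrogen in a ring, comes with a 2.5-fold higher number from compound 2 to compound 3 (0.39 log units; beyond the scatter). Going by these compounds alone, this is the first comparison here that differs in one place only, so this shift can be tied to the chain change, and the longer chain lies on the weaker side. The step is modest, and a single step gives no trend along the chain.

On these data alone, whether a shorter chain, a longer chain still, or an amine in place of the chain oxygen would move the number further stays open. So does whether the same change would give a similar step on the core of compound 1. No measurement at hand gives a reason for this step.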